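Methyl to Cyano on the Benzyl Ring of Compound 1

The source may report more compounds than this note shows. Statements on the series, on what has been measured and on what is new or still open speak of the compounds shown alone.

Measured so far:
- compound 1, `Cc1cccc(Cc2nc3cc(O[C@H]4CC[C@@H](C(=O)O)CC4)ccc3n2C)c1`: 30 nM
- compound 2, `Cc1cccc(Cc2cc3cc(O[C@H]4CC[C@@H](C(=O)O)CC4)ccc3n2C)c1`: 400 nM

Of the compounds shown here, two have been tested in an assay on isolated protein for inhibition of Long-chain-fatty-acid--CoA ligase 1 (Mus musculus), read by mass spectrometry, with a stated time of 90 min, in the presence of a further agent that is not named here; a lower number here means a stronger inhibitor, a higher number a weaker inhibitor. Compound 1 has the structure `Cc1cccc(Cc2nc3cc(O[C@H]4CC[C@@H](C(=O)O)CC4)ccc3n2C)c1` and gives 30 nM. Compound 2, `Cc1cccc(Cc2cc3cc(O[C@H]4CC[C@@H](C(=O)O)CC4)ccc3n2C)c1`, differs in its shared core and gives 400 nM. Of the two numbers, compound 1 stands at the lower one, and the gap between compound 1 and compound 2 lies beyond the usual scatter of repeated measurements, so compound 1 is the stronger inhibitor of the pair.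

The next compound, compound 3, has the structure `Cn1c(Cc2cccc(C#N)c2)nc2cc(O[C@H]3CC[C@@H](C(=O)O)CC3)ccc21`. It keeps the core and the acid-bearing ring of compound 1 and alters only the pendant aromatic ring: cyano in place of methyl on an aromatic carbon. Among the compounds with values here, no measured pair shows this particular exchange, so there is no direct precedent for its effect on this assay. Since nothing shown bears on it, the expectation is a small step in either direction, likely within the scatter, and the estimated step from compound 1 to compound 3 is a 1.7-fold higher number from compound 1 to compound 3 (0.22 log units; within the scatter). Compound 3 is therefore expected to give about 50 nM, in a range from 10 nM to 250 nM.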

Compound 3, half-maximal inhibitory concentration: 22000 nM
For compound 3 the middle estimate is 440-fold (2.64 log units) below the measured one; the measured number lies above the stated range.
By their numbers in this assay, from the lowest: compound 1; then compound 2; then compound 3.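

In this assay, putting cyano in place of methyl on this aromatic carbon gives a 730-fold higher number from compound 1 to compound 3 (2.87 log units; beyond the scatter), so a change confined to the pendant ring, with the core and the acid-bearing ring untouched, can decide whether the compound is a strong or a very weak inhibitor. Within the data shown here, compound 1 and compound 2 differ only in the shared core, so they gave no information about this ring, and this is the first sign of how sensitive this position is to the group it carries. Nothing measured here explains why this particular exchange has so large an effect.

With only methyl and cyano shown at this carbon, it remains open whether methyl is unusually favourable or cyano is unusually unfavourable, and an ethyl group, a chlorine atom or a methoxy group in the same place would help to separate the two. Among these compounds, it is also open whether the same exchange would have a similar effect on the core of compound 2, since that pair has no counterpart here carrying cyano.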